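Capping the Free Amine of Compound 1

The source may hold more compounds than are shown below. What is called first, only, known or untested is meant among the compounds shown, and "the series" means these compounds.

Of the compounds shown here, two sharing one core have so far been measured in a functional assay on A549 cells (Homo sapiens) for cytotoxicity, read by MTT assay, with a stated time of 68 h; a higher number here means a weaker inhibitor, a lower number a stronger inhibitor. Compound 1 `Nc1cccc(-c2cccc(NC(=O)C(Cl)Cl)c2)c1` carries a free amino group on its second aromatic ring, and in this assay compound 1 gives 50000 nM. Compound 2 `Cc1ccccc1-c1cccc(NC(=O)C(Cl)Cl)c1` has a methyl group where compound 1 has the amine, and in this assay compound 2 gives 9860 nM. Of the two numbers, compound 1 stands at the highest, with compound 2 the nearest, and that gap lies beyond the usual scatter, so compound 2 is the stronger inhibitor of the pair.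

The step followed here runs from compound 1 to compound 3 `O=C(Nc1cccc(-c2cccc(NC(=O)C(Cl)Cl)c2)c1)C(Cl)Cl`, in which the free amine is capped. Counted from the two structures, the difference is (dichloromethyl)carbonyl in place of hydrogen on a nitrogen on an aromatic ring. For the measured compounds named here, no measured pair shows exactly this change, so its size cannot be read off; it can only be expected. The comparison of compound 1 with compound 2 points toward a stronger inhibitor once the free amine is gone, because compound 2 at 9860 nM sits well under compound 1 at 50000 nM.

The step from compound 1 to compound 3 is therefore expected to be a 5.0-fold lower number from compound 1 to compound 3 (0.70 log units; beyond the scatter), toward a stronger inhibitor. Compound 3 is estimated at 10000 nM, within a range from 3000 nM to 35000 nM.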

Compound 3, half-maximal inhibitory concentration: 47900 nM
Compound 3: the middle estimate sits 4.8-fold (0.68 log units) below what was measured; the measured number lies above the stated range.
By their numbers in this assay, from the lowest: compound 2; then compounds 3 and 1 (each within the scatter of the next).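

Replacing the hydrogen on this nitrogen with (dichloromethyl)carbonyl gives, in this assay, a 1.0-fold lower number from compound 1 to compound 3 (0.02 log units; within the scatter) and so leaves compound 1 and compound 3 within the scatter of each other. For the compounds shown here, this is what the earlier compounds could not show: at this nitrogen on an aromatic ring, going from amino to ((dichloromethyl)carbonyl)amino, with 5 heavy atoms entering and the free amine gone, gives no readable difference in this read-out. Capping the amine with this group is therefore not enough on its own to give a stronger inhibitor in these cells, and nothing available here bears on why the two compounds read alike.

Still open, from the compounds shown here alone, is whether a smaller acyl group such as acetyl, a longer chain such as hexanoyl, or a methyl group on the same nitrogen would also stay within the scatter of compound 1. Going by these compounds, it is equally open whether a methanesulfonyl group or a carboxylic acid at this place would separate from compound 1 in this assay at all.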